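A few compounds are considered here, and "the series" means these few. Any claim that something is new, unique, unknown or untested is made for them only; others in the source may bear on it.

Compound 1 `Cc1ccnc(NC(c2ccc(F)cc2)c2ccc3cccnc3c2O)c1` stands at the low end of the numbers gathered so far: in an assay for inhibition of protein disulfide-isomerase (Homo sapiens), with a stated time of 1 h (on this read-out higher numbers stand for weaker inhibition and lower numbers for stronger inhibition), compound 1 gives 140 nM, the lowest of the two numbers shown. Compound 3 `Cc1ccnc(NC(c2cccc(F)c2)c2ccc3cccnc3c2O)c1` gives 350 nM in this assay. Compound 2 `Cc1ccnc(NC(c2ccccc2C)c2ccc3cccnc3c2O)c1` gives only a limit of this assay, > 40000 nM, and no number. The three compounds differ only in the aryl ring attached to the saturated chain carbon of the shared core. Moving the fluorine around that ring produced a 2.5-fold higher number from compound 1 to compound 3 (0.40 log units; beyond the scatter), while exchanging it for a 2-methylphenyl gave an at least 280-fold higher number from compound 1 to compound 2 (2.45 log units; beyond the scatter) and, read the other way, an at least 110-fold lower number from compound 2 to compound 3 (2.05 log units; beyond the scatter); the one compound at the limit of > 40000 nM in this assay, at which 1 of the 3 values shown sits, is the one carrying that group.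

Compound 4 `Cc1ccnc(NC(c2ccc(OCc3ccccc3)cc2)c2ccc3cccnc3c2O)c1` is not yet measured. It differs from compound 1 by benzyloxy in place of fluoro on an aromatic carbon. All three measured steps bear on it, since they alter the same aryl ring, yet none introduces a group of this size at this position. The measured steps show that changes to the aryl ring can range from modest to large, and the largest one occurred only with the 2-methylphenyl. For compound 4 a modest weakening beyond the scatter is therefore expected, a 2.5-fold higher number from compound 1 to compound 4 (0.40 log units; beyond the scatter). Compound 4 is estimated at 350 nM, with a range from 70 nM to 2000 nM.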

Compound 4, half-maximal inhibitory concentration: 620 nM
Compound 4: the middle estimate sits 1.8-fold (0.25 log units) below what was measured, within the range that was stated.
By their numbers in this assay, from the lowest: compound 1; then compounds 3 and 4 (each within the scatter of the next). At a limit, above all of these: compound 2.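

Swapping fluoro for benzyloxy brings in a whole added six-membered aromatic ring and a hydrogen-bond acceptor, yet on this carbon, para to a large group, it costs only a modest step, a 4.4-fold higher number from compound 1 to compound 4 (0.65 log units; beyond the scatter). For the compounds shown here, the earlier compounds changed this ring only by a fluorine's place or a methyl-bearing ring, so compound 4 is the first to show that a group far larger than fluoro at this position still gives a measured number in this assay, one that lies within the scatter of the number for compound 3. Of the four compounds, only compound 2 remains at a limit and not a number: the limit of > 40000 nM in this assay, at which 1 of the 4 values shown sits.

Going by these compounds, what stays open is whether a methoxy group here would read like fluoro or like benzyloxy, which would show whether the added aromatic ring of benzyloxy matters at all, and how an amine, a carboxylic acid or a longer chain would read at this position. Also open, on these data alone, is whether a methyl group in place of the fluoro of compound 1 would read like compound 1 or like compound 2.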